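A few compounds are considered here, and "the series" means these few. Any claim that something is new, unique, unknown or untested is made for them only; others in the source may bear on it.

Compound 1 `O=S(=O)(Nc1ccc2oc(-c3ccccc3)nc2c1)c1ccc(Cl)c(Cl)c1` gives 71000 nM in an ADME assay on HEK293 cells (Homo sapiens) for cytotoxicity, read by resazurin assay, with a stated time of 48 h; a higher number here means that more compound is tolerated, a lower number that less compound is tolerated. Compound 2 `O=S(=O)(Nc1ccc(-c2nc3ccccc3o2)cc1)c1ccccc1C(F)(F)F` reaches only a limit of this assay, > 100000 nM. Compound 3 `O=S(=O)(Nc1ccc(-c2nc3ccccc3o2)cc1)c1ccccc1O` likewise reaches only a limit, > 100000 nM.

Compound 3 thus stands at the limit of > 100000 nM in this assay, at which 2 of the 3 values shown sit, and the step that the two limits leave unreadable from compound 2 to compound 3 stays hidden behind those limits. Compound 4 `O=S(=O)(Nc1ccc(-c2nc3ccccc3o2)cc1)c1ccc(Cl)s1` differs from compound 3 by 5-chlorothiophen-2-yl in place of 2-hydroxyphenyl on a sulfonyl sulfur. Within the data shown here, no measured step touches the sulfonyl substituent with readable numbers, so nothing here sets a direction; the one readable value, from compound 1, sits not far from the limit. The step of an at least 1.2-fold lower number from compound 3 to compound 4 (0.09 log units; that floor lies within the scatter) is therefore expected to be small, if any. Compound 4 is estimated at 80000 nM, within 30000 nM to 200000 nM, in this assay.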

Compound 4, half-maximal cytotoxic concentration: > 100000 nM
Compound 4 ended at the assay's limit (the forecaster's own chance of this, stated with the estimate: 55%); middle value at least 1.2-fold (0.09 log units) from the limit.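

In this assay, among these compounds, compound 3 and compound 4 both stand only at a limit, so no step between them can be read. Still open, from the compounds shown here alone, is whether changing the group on the sulfonyl sulfur alters how much compound is tolerated.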